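Swapping Anilino for Azido: From Compound 2 to Compound 4

A few compounds are considered here, and "the series" means these few. Any claim that something is new, unique, unknown or untested is made for them only; others in the source may bear on it.

Of the compounds shown here, three have been measured in a functional assay on the whole organism (Pleural cavity) with Rattus norvegicus as the target; a higher number here means that more compound is needed for the effect, a lower number that less compound is needed. Compound 1 `CSc1[nH]ccc2ncnc1-2` gives 9 mg/kg. For compound 2 `OC[C@H]1OC(n2cnc3c(Nc4ccccc4)nccc32)[C@H](O)[C@@H]1O` only a limit is known, > 9 mg/kg. Compound 3 `CN(C)c1nccc2c1ncn2[C@H]1C[C@H](O)[C@@H](CO)O1` likewise gives only a limit, > 9 mg/kg. Compound 2 therefore sits at the limit of > 9 mg/kg in this assay, at which 2 of the 3 values shown sit, and its numbers do not set it apart from compound 3. The unmeasured compound 4 `[N-]=[N+]=Nc1nccc2c1ncn2C1O[C@H](CO)[C@@H](O)[C@H]1O` differs from compound 2 in one place: azido in place of anilino on an aromatic carbon. For the measured compounds named here, no measured pair shares this change, and compound 2 is known only as a limit, so the numbers give no direction. Compound 4 is expected to stay near that limit, with the step that the limit leaves unreadable from compound 2 to compound 4 expected to lie within scatter. The estimate for compound 4 in this assay is 12 mg/kg, expected between 5 mg/kg and 40 mg/kg.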

Compound 4, dose for half-maximal effect: > 9 mg/kg
Compound 4 was reported as a limit; the forecaster's own chance of this, stated with the estimate: 60%; the middle value is on the limit's open side.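

Compound 2 and compound 4 are both known only as limits in this assay, so no step can be read between them. From the compounds shown here alone, whether azido in place of anilino on this aromatic carbon shifts the dose remains open.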